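Sulfonyl aryl swap, cyclopropyl methine series

This account rests on a few compounds, and the source may have more. Where it says the series, first, only, none or still open, it means among the compounds named here.

For the measured compounds named here, compound 1 `N#Cc1ccc(S(=O)(=O)Nc2cccc([C@@H](c3c(O)oc4c(c3=O)CCCCCC4)C3CC3)c2)cc1` is one of only two compounds measured so far in an in vivo ADME assay on the whole organism with Rattus norvegicus as the target, at a dose of 5 mg/kg by the oral route (on this read-out higher numbers stand for higher exposure at the dose given and lower numbers for lower exposure), where compound 1 gives 19000 nM. The other is compound 2 `N#Cc1ccc(S(=O)(=O)Nc2cccc([C@H](c3c(O)oc4c(c3=O)CCCCCC4)C3CC3)c2)cc1`, which in this assay gives 13000 nM; the step of a 1.5-fold lower number from compound 1 to compound 2 (0.16 log units; within the scatter) lies within the scatter, and the pair rests on (the fact that compounds 1 and 2 differ only in the configuration as drawn). Compound 3 `O=c1c2c(oc(O)c1[C@H](c1cccc(NS(=O)(=O)c3cccc4cccnc34)c1)C1CC1)CCCCCC2` is not yet measured. It differs from compound 1 by quinolin-8-yl in place of 4-cyanophenyl on a sulfonyl sulfur. Going by the values given here, no measured step touches this change: the one step in hand, a 1.5-fold lower number from compound 1 to compound 2 (0.16 log units; within the scatter), alters configuration only and says nothing about the aryl on the sulfonyl sulfur. There is therefore no basis for a step beyond the scatter in either direction, and the range must stay wide. For compound 3 the expected value in this assay is 12000 nM, between 3500 nM and 40000 nM. The expected step of a 1.6-fold lower number from compound 1 to compound 3 (0.20 log units; within the scatter) is thus essentially flat.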

Compound 3, maximal plasma concentration: 6200 nM
Compound 3: the middle estimate sits 1.9-fold (0.29 log units) above what was measured; the range from low to high includes it.
By their numbers in this assay, from the lowest: compound 3; then compounds 2 and 1 (each within the scatter of the next).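

In this assay, quinolin-8-yl in place of 4-cyanophenyl on a sulfonyl sulfur gives a 3.1-fold lower number from compound 1 to compound 3 (0.49 log units; beyond the scatter), whereas the change of configuration alone gives a 1.5-fold lower number from compound 1 to compound 2 (0.16 log units; within the scatter). Oral maximal plasma concentration in the rat therefore responds to the aryl on the sulfonyl sulfur, and this is the only step shown that lies beyond the scatter. Nothing at hand gives a measured property that bears on this step.

The swap removes the nitrile and brings in a second ring and a ring nitrogen together, so the step cannot be assigned to any one of these features. Open questions are where a plain phenyl or a naphthyl group on the sulfonyl sulfur would fall, and whether the step holds in the opposite configuration.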